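This account rests on a few compounds, and the source may have more. Where it says the series, first, only, none or still open, it means among the compounds named here.

Compound 1 `COc1ccc(-c2cc(/C=C/C(=O)c3ccc(N)cc3)[nH]n2)cc1` is one of three close analogues sharing a core. In a functional assay on NCI-H23 cells (Homo sapiens) for inhibition, read by sulforhodamine B assay, with a stated time of 48 h (on this read-out higher numbers stand for weaker inhibition of growth and lower numbers for stronger inhibition of growth), compound 1 gives 13100 nM. Among the measured compounds shown here, compound 2 `COc1ccc(C(=O)/C=C/c2cc(-c3cc(OC)c(OC)c(OC)c3)n[nH]2)cc1` gives 12200 nM in this assay, and compound 3 `COc1cc(-c2cc(/C=C/C(=O)c3ccc(F)c(F)c3)[nH]n2)cc(OC)c1OC` gives 8500 nM; the only single-point step among them, a 1.4-fold lower number from compound 2 to compound 3 (0.16 log units; within the scatter), lies within the scatter, so no compound is set apart from compound 1 beyond the scatter.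

Compound 4 `COc1ccc(-c2cc(/C=C/C(=O)c3ccc(N)cc3)[nH]n2)cc1OC` differs from compound 1 by methoxy in place of hydrogen on an aromatic carbon. For the measured compounds named here, no measured step here tests adding a methoxy group to that ring, and the one step available changed a different part of the molecule without effect beyond the scatter. A change of no more than the scatter is therefore expected, a 1.2-fold lower number from compound 1 to compound 4 (0.08 log units; within the scatter), and compound 4 is estimated at 11000 nM, ranging from 4500 nM to 27000 nM.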

Compound 4, concentration for total growth inhibition: 19300 nM
Compound 4: middle estimate off by 1.8-fold (0.24 log units), on the low side; the measured number falls inside the stated range.
By their numbers in this assay, from the lowest: compounds 3, 2, 1 and 4 (each within the scatter of the next, the first and the last beyond it).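

Placing methoxy on this aromatic carbon, ortho to a methoxy group and meta to a large group, gives a 1.5-fold higher number from compound 1 to compound 4 (0.17 log units; within the scatter) in this assay. The position therefore takes this added group with no shift that can be told apart from the scatter of repeated measurements. Nothing measured here offers an explanation for this result. Going by these compounds, whether a hydroxyl or an ethoxy group on the same carbon would move the number beyond the scatter stays open.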